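Cyclohexylmethyl in place of 4-hydroxycyclohexyl: working notes

The compounds below may be only part of what the source reports. "The series", "measured", "known", "first", "only" and "open" are said of these compounds alone.

Of the compounds shown here, three have numbers so far in an ADME assay on MRC5 cells (Homo sapiens) for inhibition, with a stated time of 72 h; a higher number here means that more compound is needed for the effect, a lower number that less compound is needed. Compound 1 `CCc1ccccc1C(=O)Nc1c[nH]nc1C(=O)N[C@H]1CC[C@H](OC)CC1` gives 3400 nM. Compound 2 `COc1cccc(OC)c1C(=O)Nc1c[nH]nc1C(=O)NC1CCN(Cc2ccccc2)C1` gives 38000 nM. Compound 3 `COc1cccc(OC)c1C(=O)Nc1c[nH]nc1C(=O)N[C@H]1CC[C@H](O)CC1` gives 34000 nM, within the scatter of compound 2 and clearly higher than compound 1.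

Compound 4 `COc1cccc(OC)c1C(=O)Nc1c[nH]nc1C(=O)NCC1CCCCC1` carries cyclohexylmethyl in place of 4-hydroxycyclohexyl on an amide-type nitrogen. Among the compounds with values here, no measured pair differs in one place only, so nothing gauges this change directly. The lower number of compound 1 comes with a change in more than one place and cannot be assigned to this substituent alone. Compound 2 has a quite different group on the same amide-type nitrogen and still gives 38000 nM, so no step beyond the scatter is expected in this assay. The expected change is a 1.7-fold lower number from compound 3 to compound 4 (0.23 log units; within the scatter), with any drift more likely downward than upward. For compound 4 the estimated value is 20000 nM, with an expected range of 7000 nM to 50000 nM.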

Compound 4, half-maximal effective concentration: > 50000 nM
Compound 4: only a limit was reported; the forecaster's own chance of this, stated with the estimate: 15%; middle value at least 2.5-fold (0.39 log units) from the limit.
By their numbers in this assay, from the lowest: compound 1; then compounds 3 and 2 (each within the scatter of the next). At a limit, above all of these: compound 4.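

Within the data shown here, this is the first pair that differs in one place, and cyclohexylmethyl in place of 4-hydroxycyclohexyl on the amide-type nitrogen gives an at least 1.4-fold higher number from compound 3 to compound 4 (0.16 log units; that floor lies within the scatter). In this assay compound 4 gives > 50000 nM, which is a limit and not a number. The pair therefore shows no fall in the number when the hydroxyl-bearing group leaves, although how far the step extends cannot be read: the limit of > 50000 nM in this assay, at which 1 of the 4 values shown sits.

Open, as far as these compounds go, is whether an amine or a carboxylic acid on the cyclohexyl ring of compound 4 would bring the number back within the measurable range. Also open, from the compounds shown here alone, are how a longer chain, such as cyclohexylethyl, reads on the same nitrogen and whether this change reads the same on the acyl group of compound 1.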